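Rat oral exposure across the benzothiazole-substituted aminopyrimidine series

The source may report more compounds than this note shows. Statements on the series, on what has been measured and on what is new or still open speak of the compounds shown alone.

Measured so far:
compound 1 `Nc1ncc(-c2nc3ccccc3s2)c(N[C@@H]2C[C@H](CO)[C@@H](O)[C@H]2O)n1`: 149 ng.h/mL
compound 2 `CCOC(=O)NCCNc1nc(C)c(-c2nc3ccccc3s2)c(N[C@@H]2C[C@H](CO)[C@@H](O)[C@H]2O)n1`: 151 ng.h/mL

Both compounds were run in an ADME assay on the whole organism (plasma) for pharmacokinetics, with Rattus norvegicus as the target, with a stated time of 6 h, at a dose of 10 mg/kg by the oral route; on this read-out lower numbers stand for lower exposure and higher numbers for higher exposure at the dose given. On this read-out compound 1 gives 149 ng.h/mL and compound 2 gives 151 ng.h/mL. Compound 2 has the highest of the two numbers, but the nearest, compound 1, lies within the scatter of it, so the two are not told apart.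

Compound 3 `Cc1nc(NCc2ccncc2)nc(N[C@@H]2C[C@H](CO)[C@@H](O)[C@H]2O)c1-c1nc2ccccc2s1` has not yet been measured in this assay. It differs from compound 2 in one place: pyridin-4-yl in place of ((ethoxycarbonyl)amino)methyl on a saturated chain carbon bound to a nitrogen on an aromatic ring. No step between measured compounds covers such a change, so there is no shown step to lean on. With both measured values so close together, a step within the scatter is expected, a 1.2-fold higher number from compound 2 to compound 3 (0.08 log units; within the scatter), with wide uncertainty in either direction. For compound 3 the expected value in this assay is 180 ng.h/mL, within a range from 60 ng.h/mL to 550 ng.h/mL.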

Compound 3, area under the concentration-time curve: 47.9 ng.h/mL
The estimate for compound 3 lay 3.8-fold (0.57 log units) above the measured number; measured number below the stated range.
By their numbers in this assay, from the lowest: compound 3; then compounds 1 and 2 (each within the scatter of the next).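

In this assay, this position can move the read-out: pyridin-4-yl in place of ((ethoxycarbonyl)amino)methyl, on a saturated chain carbon bound to a nitrogen on an aromatic ring, gives a 3.2-fold lower number from compound 2 to compound 3 (0.50 log units; beyond the scatter). This is the only one-place step shown for the series, and compounds 1 and 2 differ in more than one place, so they could not show this. The entering group has one six-membered aromatic ring and 0 hydrogen-bond donors, while the leaving group has no ring and 1 hydrogen-bond donor, but no measurement available explains the lower number.

One step cannot tell whether the lower number follows from the arrival of pyridin-4-yl or the loss of ((ethoxycarbonyl)amino)methyl. A phenyl ring or a primary amine at the same place could separate these two readings.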